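The source may report more compounds than this note shows. Statements on the series, on what has been measured and on what is new or still open speak of the compounds shown alone.

Of the compounds shown here, three that share one core have so far been tested in a functional assay on DU-145 cells (Homo sapiens) for cytotoxicity, read by MTT assay; a lower number here means a stronger inhibitor, a higher number a weaker inhibitor. Compound 1 `CCCCCCCCC(CCCCCCCCC(=O)OC)SCC(=O)NCC(=O)OC` gives 30800 nM. Compound 2 `CCCCCCCCC(CCCCCCCCC(=O)OC)SCC(=O)N[C@H](C(=O)OC)[C@@H](C)CC` gives 19000 nM. Compound 3 `CCCCCCCCC(CCCCCCCCC(=O)OC)SCC(=O)N[C@@H](CC(C)C)C(=O)OC` gives 215000 nM, the highest of the three numbers, so compound 3 is the weakest inhibitor among them.

The step now followed leads from compound 3 to compound 4 `CCCCCCCCC(CCCCCCCCC(=O)OC)SCC(=O)N[C@H](C(=O)OC)c1ccccc1`; the change is phenyl in place of isobutyl on a saturated chain carbon bound to an amide-type nitrogen and a carbonyl carbon. Two of the measured steps concern the same position. The step of a 7.0-fold higher number from compound 1 to compound 3 (0.84 log units; beyond the scatter) and the step of an 11-fold higher number from compound 2 to compound 3 (1.05 log units; beyond the scatter) both show that isobutyl at this position gives a weaker inhibitor than hydrogen or sec-butyl. The step of a 1.6-fold lower number from compound 1 to compound 2 (0.21 log units; within the scatter) shows no clear difference between those two. For the measured compounds named here, no measured step involves phenyl, so the direction of the new step is not fixed by the data; removing isobutyl is the only part that has a precedent.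

Taking that into account, compound 4 is expected to show a step of a 3.6-fold lower number from compound 3 to compound 4 (0.55 log units; beyond the scatter), giving an estimated 60000 nM, with a range from 15000 nM to 250000 nM.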

Compound 4, half-maximal inhibitory concentration: 49100 nM
Compound 4: middle estimate off by 1.2-fold (0.09 log units), on the high side; low and high end bracket the measured number.
By their numbers in this assay, from the lowest: compounds 2, 1 and 4 (each within the scatter of the next, the first and the last beyond it); then compound 3.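

In this assay, phenyl brings the first ring to this position, on a saturated chain carbon bound to an amide-type nitrogen and a carbonyl carbon, and replacing isobutyl with it gives a 4.4-fold lower number from compound 3 to compound 4 (0.64 log units; beyond the scatter). Replacing hydrogen with phenyl gives a 1.6-fold higher number from compound 1 to compound 4 (0.20 log units; within the scatter), while replacing sec-butyl with phenyl gives a 2.6-fold higher number from compound 2 to compound 4 (0.41 log units; beyond the scatter), so phenyl cannot be told apart from hydrogen here but does fall short of sec-butyl. Compound 3 remains the weakest inhibitor, which shows that the loss seen with isobutyl does not extend to every group with more heavy atoms than hydrogen.

No measurement offers a reason for these differences. Going by these compounds, whether a benzyl group at this position would behave more like phenyl or more like isobutyl remains open.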